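Adding a Second Methoxy Group to Compound 2

The compounds below may be only part of what the source reports. "The series", "measured", "known", "first", "only" and "open" are said of these compounds alone.

Compound 2 `COc1ccc(-c2cnc3nc(N)nc(OC(C)C)c3n2)cc1` sits at the edge of what the measurement can report. In a functional assay on cells (T-cell, Homo sapiens) for inhibition (a higher number here means a weaker inhibitor, a lower number a stronger inhibitor), compound 2 gives > 10000 nM, which is a limit of the assay and not a number. Compound 3 `CCOc1nc(N)nc2ncc(-c3ccc(OC)cc3)nc12` differs from compound 2 by hydrogen in place of methyl on a saturated chain carbon bound to an oxygen on an aromatic ring and a saturated chain carbon; in this assay compound 3 gives > 10000 nM, again a limit. The step that the two limits leave unreadable from compound 2 to compound 3 cannot be read because of the limit of > 10000 nM in this assay, at which 2 of the 3 values shown sit. Compound 1 `COc1ccc(-c2cnc3nc(N)nc(N4CCC(C)CC4)c3n2)cc1OC` differs from compound 2 in two places rather than one; in this assay compound 1 gives 800 nM.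

Compound 4 `COc1ccc(-c2cnc3nc(N)nc(OC(C)C)c3n2)cc1OC` has not yet been measured. It differs from compound 2 by methoxy in place of hydrogen on an aromatic carbon. For the measured compounds named here, no measured step in this set tracks that particular change, and the single measured step is itself unreadable, so nothing here fixes a direction or size. Given that compound 2 stands only at a limit, compound 4 is expected to give about 10000 nM, with a plausible range from 2000 nM to 40000 nM. This estimate means an expected step of a number no higher from compound 2 to compound 4 (the limit leaves the size open), with a fair chance that the assay again reports only a limit.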

Compound 4, half-maximal inhibitory concentration: 400 nM
Compound 4: middle estimate off by 25-fold (1.40 log units), on the high side; measured number outside the range, below it.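

In this assay, for the compounds shown here, a methoxy group on this aromatic carbon, ortho to the methoxy group already on the ring, is the first single change here whose effect can be read, and it gives an at least 25-fold lower number from compound 2 to compound 4 (1.39 log units; beyond the scatter). That step marks only a minimum size, not an exact one, because compound 2 stands at a limit and not at a number: the limit of > 10000 nM in this assay, at which 2 of the 4 values shown sit. With the second methoxy group in place, the isopropoxy compound is no longer stuck at the limit, and isopropoxy in place of 4-methylpiperidin-1-yl gives a 2.0-fold lower number from compound 1 to compound 4 (0.30 log units; within the scatter), so this swap does not separate the two compounds.

Going by these compounds, what a hydroxyl group, a fluorine atom or an ethoxy group on this same aromatic carbon would do remains open, as does whether the effect depends on the methoxy group already on the ring. Also open, on these data alone, is whether the second methoxy group would have a similar effect with the ethoxy group of compound 3 on the shared core, and why this change matters at all.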